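Dichlorophenyl in place of aminophenyl on the trimethoxyphenyl pyrazole chalcone

A few compounds are considered here, and "the series" means these few. Any claim that something is new, unique, unknown or untested is made for them only; others in the source may bear on it.

Measured so far:
compound 1 `COc1cc(-c2cc(/C=C/C(=O)c3ccc(N)cc3)[nH]n2)cc(OC)c1OC`, 82%
compound 2 `COc1ccc(-c2cc(/C=C/C(=O)c3ccc(OC)c(OC)c3)[nH]n2)cc1`, 65%

In a functional assay on SW-620 cells (Homo sapiens) for cytotoxicity, read by sulforhodamine B assay, with a stated time of 48 h, tested at 1 uM (a lower number here means a stronger effect, a higher number a weaker effect of the compound at the concentration tested), compound 1 gives 82%, the highest of the two numbers at hand, which means the weaker effect of the two. Compound 2 gives 65% in this assay, a number lower than that of compound 1 by more than the usual scatter. Among the compounds with values here, compound 1 and compound 2 differ in more than one place, so no single step between them can be read off.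

Compound 3 `COc1cc(-c2cc(/C=C/C(=O)c3ccc(Cl)c(Cl)c3)[nH]n2)cc(OC)c1OC` has not yet been measured in this assay. It differs from compound 1 as follows: 3,4-dichlorophenyl in place of 4-aminophenyl on a carbonyl carbon. Within the data shown here, since no measured pair shows this change by itself, the only guide is the wide spread of values that the two measured compounds already show.

Compound 3 is estimated to give 75% in this assay, with a range from 55% to 95%. The expected step of a number 7 percentage points lower from compound 1 to compound 3 (within the scatter) is a modest move towards the stronger side, though it may well fall within the scatter.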

Compound 3, a percentage reported as activity, at one concentration (the size of the read-out at that concentration, not a potency): 91%
For compound 3 the middle estimate is 16 percentage points below the measured one; the measured number falls inside the stated range.
By their numbers in this assay, from the lowest: compound 2; then compounds 1 and 3 (each within the scatter of the next).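

In this assay, the swap of 4-aminophenyl for 3,4-dichlorophenyl on the carbonyl carbon gives a number 9 percentage points higher from compound 1 to compound 3 (within the scatter), so the two compounds cannot be told apart at the concentration tested. Within the data shown here, this is the first single-place comparison, and it shows that this position can carry either aryl group, one with a hydrogen-bond donor and acceptor and the other with neither and with two chlorines, without a readable difference in this read-out. No measurement that could explain why the two groups read alike is at hand.

On these data alone, whether this holds for other groups on the core of compound 1, such as a pyridine ring in place of the phenyl ring or a phenyl ring bearing a carboxylic acid, remains open, as does whether the same swap would read alike on the core of compound 2. Compound 2 differs from both compound 1 and compound 3 in more than one place. The compounds shown do not reveal which of its features goes with its separate position in the series.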